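A few compounds are considered here, and "the series" means these few. Any claim that something is new, unique, unknown or untested is made for them only; others in the source may bear on it.

Measured so far in a functional assay on MCF7 cells (Homo sapiens) for antiproliferative activity; a higher number here means a weaker inhibitor, a lower number a stronger inhibitor:
- compound 1 `COc1ccc(C(=O)Nc2ccc(O)c3c(=O)cc(-c4ccccc4Cl)oc23)cc1` gives 3500 nM
- compound 2 `O=C(Nc1c(O)cc(O)c2c(=O)cc(-c3ccccc3Cl)oc12)c1ccc(Cl)cc1` gives 13000 nM
- compound 3 `Cc1ccc(C(=O)Nc2c(O)cc(O)c3c(=O)cc(-c4ccccc4Cl)oc23)cc1` gives 9700 nM

Compound 3 sits in the upper pair of these numbers, level with compound 2 within the scatter, while compound 1 has a lower number, beyond the scatter.

Compound 4 `COc1ccc(C(=O)Nc2c(O)cc(O)c3c(=O)cc(-c4ccccc4Cl)oc23)cc1` has not yet been measured. It differs from compound 3 as follows: methoxy in place of methyl on an aromatic carbon, which means methoxy in place of methyl on an aromatic carbon, para to a large group.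

Among the compounds with values here, the only measured step at this place is a 1.3-fold lower number from compound 2 to compound 3 (0.13 log units; within the scatter), methyl in place of chloro on an aromatic carbon, so no step beyond the scatter is expected in this assay and no direction is favoured. Within the data shown here, no measured step brings in a methoxy group, so a single step is thin support and the range stays wide.

The estimated change is a 1.1-fold lower number from compound 3 to compound 4 (0.03 log units; within the scatter), which amounts to no real shift. Compound 4 is expected at 9000 nM, with an estimated range of 4000 nM to 20000 nM in this estimate.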

Compound 4, half-maximal inhibitory concentration: 13000 nM
For compound 4 the middle estimate is 1.4-fold (0.16 log units) below the measured one, within the range that was stated.
By their numbers in this assay, from the lowest: compound 1; then compounds 3, 2 and 4 (each within the scatter of the next).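

Methoxy now joins methyl and chloro at this place on the aromatic ring, and in this assay the swap changes little: there is a 1.3-fold higher number from compound 3 to compound 4 (0.13 log units; within the scatter) and no change at the digits printed from compound 2 to compound 4 (within the scatter), so the three groups read alike here. Within the data shown here, the one step beyond the scatter lies elsewhere: with methoxy held fixed, hydroxy in place of hydrogen on an aromatic carbon of the core gives a 3.7-fold higher number from compound 1 to compound 4 (0.57 log units; beyond the scatter), which ties the gap around compound 1 to that single change. No supporting measurement bears on why the numbers fall this way.

On these data alone, whether an amine, a carboxylic acid or a longer chain such as ethoxy at this place would move the number remains open. As far as these compounds go, the hydroxy step is also read only with methoxy present, so its size with methyl or chloro stays unknown.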